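This account rests on a few compounds, and the source may have more. Where it says the series, first, only, none or still open, it means among the compounds named here.

Compound 1 `CN1CCN(c2ccc(Nc3ncc4nc(SCc5cccnc5)n(C5CCOCC5)c4n3)cc2)CC1` gives 500 nM
Compound 2 `CN1CCN(c2ccc(Nc3ncc4nc(Sc5ccccc5)n(C5CCCC5)c4n3)cc2)CC1` gives 51.2 nM

In a functional assay on HCC827 cells (Homo sapiens) for antiproliferative activity, read by MTT assay, with a stated time of 72 h (a lower number here means a stronger inhibitor, a higher number a weaker inhibitor), compound 2 holds the lower of these two numbers, and its gap to compound 1 lies beyond the scatter of repeated measurements. Compound 3 `CN1CCN(c2ccc(Nc3ncc4nc(SCc5cccnc5)n(C5CCCC5)c4n3)cc2)CC1` has (pyridin-3-yl)methyl in place of phenyl on a sulfur. Compound 1 also carries that group on a sulfur and gives 500 nM as its number, so compound 3 is expected to be a weaker inhibitor than compound 2, probably by a step beyond the scatter. The estimated step runs upward (a 2.5-fold higher number from compound 2 to compound 3 (0.40 log units; beyond the scatter)). Compound 3 is expected at 130 nM within an estimated range (40 nM to 450 nM).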

Compound 3, half-maximal inhibitory concentration: 517 nM
Compound 3: the middle estimate sits 4.0-fold (0.60 log units) below what was measured; the whole stated range lies below it.
By their numbers in this assay, from the lowest: compound 2; then compounds 1 and 3 (each within the scatter of the next).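

In this assay, the sulfur position is sensitive to this change: putting (pyridin-3-yl)methyl in place of phenyl gives a 10-fold higher number from compound 2 to compound 3 (1.00 log units; beyond the scatter). With (pyridin-3-yl)methyl on the sulfur, cyclopentyl in place of oxan-4-yl on the aromatic nitrogen gives a 1.0-fold higher number from compound 1 to compound 3 (0.01 log units; within the scatter), so this pair shows no difference beyond the scatter. No evidence is available to explain either result. As far as these compounds go, whether the loss follows the added carbon link or the ring nitrogen stays open; benzyl on the sulfur would help separate the two. Also open, from the compounds shown here alone, is whether oxan-4-yl and cyclopentyl still match with phenyl on the sulfur.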